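A few compounds are considered here, and "the series" means these few. Any claim that something is new, unique, unknown or untested is made for them only; others in the source may bear on it.

In a functional assay on SK-BR-3 cells (Homo sapiens) for antiproliferative activity (a higher number here means a weaker inhibitor, a lower number a stronger inhibitor), compound 1 `CC(C)=CCc1cc(C(=O)Nc2cc3ccc(OCC4CCCNC4)c(C)c3oc2=O)ccc1O` gives 600 nM and compound 2 `CCN(C)CCCOc1ccc2cc(NC(=O)c3ccc(O)c(CC=C(C)C)c3)c(=O)oc2c1C` gives 730 nM. Going by the values given here, compound 2 therefore stands within the usual scatter of the only other measured compound. Compound 3 `CC(C)=CCc1cc(C(=O)Nc2cc3ccc(OCCCNCC(C)C)c(C)c3oc2=O)ccc1O` keeps the shared core and differs in one group: isobutylamino in place of ethyl(methyl)amino on a saturated chain carbon, three bonds along the chain from an oxygen on an aromatic ring. Isobutylamino sits in place of ethyl(methyl)amino on a saturated chain carbon, three bonds along the chain from an oxygen on an aromatic ring. Among the compounds with values here, only one measured step bears on this change: a 1.2-fold higher number from compound 1 to compound 2 (0.09 log units; within the scatter). There, 2-(ethyl(methyl)amino)ethyl replaced piperidin-3-yl in the same chain, and the number stayed within the scatter. One step is thin evidence, but it gives no reason to expect a shift beyond the scatter in this assay. The estimated change is a 1.1-fold lower number from compound 2 to compound 3 (0.05 log units; within the scatter). Compound 3 is expected at about 650 nM, with an estimated range of 300 nM to 1400 nM.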

Compound 3, half-maximal inhibitory concentration: 1030 nM
The estimate for compound 3 lay 1.6-fold (0.20 log units) below the measured number, and the stated range covers the measured number.
By their numbers in this assay, from the lowest: compounds 1, 2 and 3 (each within the scatter of the next).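

In this assay, placing isobutylamino, which adds a hydrogen-bond donor, in place of ethyl(methyl)amino gives a 1.4-fold higher number from compound 2 to compound 3 (0.15 log units; within the scatter). Replacing piperidin-3-yl with the open 2-(isobutylamino)ethyl gives a 1.7-fold higher number from compound 1 to compound 3 (0.23 log units; within the scatter), so among these three compounds, a ring-bound amine, an amine with no hydrogen-bond donor and an amine with one all stay within the scatter of one another. Nothing measured here offers an explanation for these numbers.

Because all three end in an amine, these compounds leave open what happens if a hydroxyl group or a carboxylic acid takes the place of that amine. They also leave open whether a longer chain between the oxygen and the amine would keep the number within the scatter.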